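Sulfone series: methoxy to trifluoromethyl on the pendant ring

The source may report more compounds than this note shows. Statements on the series, on what has been measured and on what is new or still open speak of the compounds shown alone.

Three compounds of the series carry a measurement in a functional assay on A549 cells (Homo sapiens) for antiproliferative activity, read by MTT assay, with a stated time of 72 h; a lower number here means a stronger inhibitor, a higher number a weaker inhibitor. Compound 1 `O=S1(=O)C=Cc2ccc(Nc3ccc(C(F)(F)F)cc3)cc21` gives 1140 nM. Compound 2 `COc1ccc(Nc2ccc3c(c2)S(=O)(=O)C=C3)cc1` gives 1220 nM. Compound 3 `COc1ccccc1Nc1cccc2c1S(=O)(=O)C=C2` gives 2590 nM, the highest number of the three; its nearest neighbour is compound 2, and the gap to compound 2 as well as to compound 1 lies beyond the scatter.

Compound 1 and compound 2 differ in one place, (trifluoromethyl in place of methoxy on an aromatic carbon). The step of a 1.1-fold lower number from compound 2 to compound 1 (0.03 log units; within the scatter) lies within the scatter, so the two values do not separate. Compound 2 and compound 3 have the same atoms joined differently; the difference between the two cores is not broken down here.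

Compound 4 `O=S1(=O)C=Cc2cccc(Nc3ccccc3C(F)(F)F)c21` is not yet measured. It differs from compound 3 by trifluoromethyl in place of methoxy on an aromatic carbon. Going by the values given here, this is the same kind of change as the one from compound 2 to compound 1, but not the same: there the trifluoromethyl sits para to a large group, here it sits ortho to a large group.

Given that the one measured instance of the change, a 1.1-fold lower number from compound 2 to compound 1 (0.03 log units; within the scatter), stayed within the scatter, the step from compound 3 to compound 4 in this assay is expected to be small, a 1.0-fold lower number from compound 3 to compound 4 (0.02 log units; within the scatter), with wider uncertainty because the placement around the group differs. Compound 4 is therefore estimated at 2500 nM, with a range from 1100 nM to 5500 nM.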

Compound 4, half-maximal inhibitory concentration: 4120 nM
Estimate against measurement, compound 4: 1.6-fold (0.22 log units) below, within the range that was stated.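

In this assay, trifluoromethyl in place of methoxy on an aromatic carbon, here ortho to a large group, gives a 1.6-fold higher number from compound 3 to compound 4 (0.20 log units; within the scatter), so compound 3 and compound 4 do not separate. Set beside the earlier instance of the same change, this step does not differ from it, and on the evidence available the change carries from one core to the other without a detectable difference: the same change on two cores in this assay, a 1.1-fold lower number (0.03 log units; within the scatter) from compound 2 to compound 1 and a 1.6-fold higher number (0.20 log units; within the scatter) from compound 3 to compound 4, 1.7-fold (0.23 log units) apart, within the scatter of two such steps. Going by these compounds alone, this rests on only two pairs, each with its own core and its own placement of the group; it shows that the exchange stayed within the scatter in both cases, but it does not show that the exchange is neutral on other cores, and it cannot separate the contribution of the core from that of the placement.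

The compounds shown leave open how a group other than methoxy and trifluoromethyl, such as an amine, a nitrile or a carboxylic acid, would read on the pendant ring of either core. Also open, as far as these compounds go, is whether the step would hold with the group placed differently on a single core, which would separate placement from core.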